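Swapping a cyanoalkyl tail for an oxetane on the triazole nitrogen

This account rests on a few compounds, and the source may have more. Where it says the series, first, only, none or still open, it means among the compounds named here.

Compound 1 `CN1C(=S)[C@@H](NC(=O)c2nc(Cc3ccccc3)n(CCCC#N)n2)COc2ccccc21` and compound 2 `CN1C(=S)[C@@H](NC(=O)c2nc(Cc3ccccc3)n(CCCCCC#N)n2)COc2ccccc21` share one core and differ only in the length of the chain that carries the nitrile. In a functional assay on HT-29 cells (Homo sapiens) for inhibition, read by luminescence and CellTiter-Glo, with a stated time of 24 h (on this read-out lower numbers stand for an effect already at smaller amounts and higher numbers for an effect only at larger amounts of compound), compound 1 gives 2400 nM, and compound 2 gives 3830 nM. The step of a 1.6-fold higher number from compound 1 to compound 2 (0.20 log units; within the scatter) shows that lengthening this chain did nothing that can be told from repeat measurements. Going by the values given here, compound 2 has the highest of the two numbers, yet its only neighbour, compound 1, sits within the scatter, so no order between them can be claimed.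

Compound 3 `CN1C(=S)[C@@H](NC(=O)c2nc(Cc3ccccc3)n(CC3COC3)n2)COc2ccccc21` replaces the whole tail. The change is oxetan-3-yl in place of 4-cyanobutyl on a saturated chain carbon bound to an aromatic nitrogen. Among the compounds with values here, no measured step covers the loss of the nitrile or the entry of a small saturated ring. Within the data shown here, the one step that touches this part, from compound 1 to compound 2, bears on it only by showing that the chain can be altered without a shift beyond the scatter. On that evidence the expected step of a 1.2-fold lower number from compound 2 to compound 3 (0.08 log units; within the scatter) in this assay is small, with the direction unknown.

Compound 3 is therefore expected to give about 3200 nM, within a range of 1000 nM to 10000 nM.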

Compound 3, half-maximal effective concentration: 2830 nM
Estimate against measurement, compound 3: 1.1-fold (0.05 log units) above; low and high end bracket the measured number.
By their numbers in this assay, from the lowest: compounds 1, 3 and 2 (each within the scatter of the next).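

In this assay the exchange of the nitrile-bearing tail for oxetan-3-yl gives a 1.4-fold lower number from compound 2 to compound 3 (0.13 log units; within the scatter) and, set against the shorter nitrile chain, the same kind of exchange gives a 1.2-fold higher number from compound 1 to compound 3 (0.07 log units; within the scatter). Going by these compounds alone, the earlier pair showed only that the chain could change length while the nitrile stayed; now, on a saturated chain carbon bound to an aromatic nitrogen, the nitrile and the open chain both leave and a four-membered non-aromatic ring enters, and the number still cannot be told apart from those of compound 1 and compound 2. Nothing at hand speaks to what lies behind these three numbers.

The compounds shown leave open whether an amine, a carboxylic acid or a plain alkyl chain without a nitrile in this place would move the number beyond the scatter. They also leave open what a bare hydrogen on that nitrogen would give, and whether a cyclobutyl ring, which has carbon where the oxetane has its oxygen, would read like compound 3.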